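The source may report more compounds than this note shows. Statements on the series, on what has been measured and on what is new or still open speak of the compounds shown alone.

Measured so far:
compound 1, `CCCCCCC(=O)CC/C=C/C=C/C(=O)NCC(C)C`, in a functional assay on cells (Platelet, Oryctolagus cuniculus) for inhibition, read by turbidimetry, with a stated time of 3 min, tested at 100 ug/mL (a lower number here means a stronger effect, a higher number a weaker effect of the compound at the concentration tested), compound 1 gives 0%
compound 2, `C/C=C/C=C/C=C\CC/C=C/C=C/C(=O)NC(C)C`, in this assay compound 2 gives 72.7%

Going by the values given here, compound 2 stands highest of the two numbers; its only neighbour, compound 1, lies far lower, beyond the scatter. The unmeasured compound 3, `C/C=C/C=C/C=C\CC/C=C/C=C/C(=O)NC(C)(C)O`, differs from compound 2 in one place: hydroxy in place of hydrogen on a saturated chain carbon bound to an amide-type nitrogen and two saturated chain carbons. Among the compounds with values here, no pair of measured compounds shows this change, so nothing measured sets its size. The step expected from compound 2 to compound 3 in this assay is a number 2.7 percentage points lower from compound 2 to compound 3 (within the scatter), none beyond the scatter. Compound 3 is estimated at 70%, with a range from 45% to 95%.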

Compound 3, a percentage reported as activity, at one concentration (the size of the read-out at that concentration, not a potency): 78.6%
Compound 3: middle estimate off by 8.6 percentage points, on the low side; low and high end bracket the measured number.
By their numbers in this assay, from the lowest: compound 1; then compounds 2 and 3 (each within the scatter of the next).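

In this assay, hydroxy in place of hydrogen on a saturated chain carbon bound to an amide-type nitrogen and two saturated chain carbons gives a number 5.9 percentage points higher from compound 2 to compound 3 (within the scatter). Going by these compounds alone, this is the first single-place change read, and at this position the step stays within the scatter. Nothing available gives a reason for this result.

As far as these compounds go, whether an amine or a carboxylic acid on this carbon would read the same remains open. Compound 1 differs from compound 2 in more than one place, so no single change accounts for the gap between their values.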